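The source may hold more compounds than are shown below. What is called first, only, known or untested is meant among the compounds shown, and "the series" means these compounds.

Measured so far:

Compound 1 `COc1ccc(F)cc1CNCCCNc1ccnc2cc(CCC(C)C)ccc12` gives 23 10^-6 cm/s.
Compound 2 `Fc1ccc(-c2ccc3c(NCCCNCc4ccco4)ccnc3c2)cc1` gives 237 10^-6 cm/s.
Compound 3 `CC(C)CCc1ccc2c(NCCCNCc3ccco3)ccnc2c1` gives 23 10^-6 cm/s.

All three numbers come from an ADME assay for permeability, using PAMPA, with a stated time of 30 min, at pH 7.4; on this read-out higher numbers stand for higher permeability and lower numbers for lower permeability. Among the measured compounds shown here, compound 3 stands level with compound 1 at the digits given, and the two together are the lowest of the three values; the only compound apart from them is compound 2, with a much higher number: a 10-fold lower number from compound 2 to compound 3 (1.01 log units; beyond the scatter). The move from compound 1 to compound 3, a swap of the group on the chain carbon bound to the amine nitrogen, left the read-out where it was: no change at the digits printed from compound 1 to compound 3 (within the scatter).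

Compound 4 `COc1ccc(Oc2ccc3c(NCCCNCc4ccco4)ccnc3c2)cc1` is not yet measured. Its change from compound 3 is 4-methoxyphenoxy in place of isopentyl on an aromatic carbon. For the measured compounds named here, of the measured steps, only the step from compound 2 to compound 3 touches the same aromatic carbon; there, isopentyl in place of 4-fluorophenyl lowered this assay by a 10-fold lower number from compound 2 to compound 3 (1.01 log units; beyond the scatter). Compound 4 restores a six-membered aromatic ring of carbon only at that position, now with an oxygen link and two hydrogen-bond acceptors, so a rise back toward compound 2 is expected, though whether the whole distance is recovered cannot be told from these three compounds alone. The estimated step is a 5.2-fold higher number from compound 3 to compound 4 (0.72 log units; beyond the scatter). Compound 4 is therefore expected to give about 120 10^-6 cm/s, within a range of 40 10^-6 cm/s to 300 10^-6 cm/s.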

Compound 4, apparent permeability: 317 10^-6 cm/s
Compound 4: middle estimate off by 2.6-fold (0.42 log units), on the low side; measured number above the stated range.
By their numbers in this assay, from the lowest: compounds 1 and 3 (each within the scatter of the next); then compounds 2 and 4 (each within the scatter of the next).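

In this assay, 4-methoxyphenoxy in place of isopentyl on this aromatic carbon gives a 14-fold higher number from compound 3 to compound 4 (1.14 log units; beyond the scatter) and so shows that the low number of compound 3 is not set by the shared core alone, since the earlier pair showed only a fall at this position. Set against 4-fluorophenyl, the same group gives a 1.3-fold higher number from compound 2 to compound 4 (0.13 log units; within the scatter) and so the oxygen link and hydrogen-bond acceptors that enter with 4-methoxyphenoxy bring no difference this read-out can separate from the scatter. Among compounds 2, 3 and 4, the two groups holding a six-membered aromatic ring of carbon only stand together, with isopentyl apart, and no measurement in hand gives a reason for this split.

As far as these compounds go, it remains open whether an aromatic ring is what matters at this carbon, which a cyclohexyl group or a chain ending in an amine there would test. From the compounds shown here alone, it is also open whether the same split holds with 5-fluoro-2-methoxyphenyl in place of furan-2-yl on the chain.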